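The source may report more compounds than this note shows. Statements on the series, on what has been measured and on what is new or still open speak of the compounds shown alone.

Three compounds sharing the core of compound 1 have been measured in a functional assay on CCRF-CEM cells (Homo sapiens) for antiproliferative activity, read by MTT assay, with a stated time of 24 h, tested at 25 uM; a lower number here means a stronger effect, a higher number a weaker effect of the compound at the concentration tested:

compound 1 `OC(CCn1nc2c(Br)c(Br)c(Br)c(Br)c2n1)c1ccc(Br)cc1` gives 109%
compound 2 `OC(CCn1nc2c(Br)c(Br)c(Br)c(Br)c2n1)c1cccc(Cl)c1` gives 118%
compound 3 `OC(CCn1nc2c(Br)c(Br)c(Br)c(Br)c2n1)c1ccc(Cl)cc1` gives 106%

Compound 1 stands second highest of the three, nearest to compound 3 and furthest from compound 2, both within the scatter. Compound 4 `OC(CCn1nc2c(Br)c(Br)c(Br)c(Br)c2n1)c1cccc(Br)c1` differs from compound 1 by 3-bromophenyl in place of 4-bromophenyl on a saturated chain carbon bound to an oxygen on a saturated carbon and a saturated chain carbon. The measured step that bears on this change is a number 12 percentage points lower from compound 2 to compound 3 (beyond the scatter), the same kind of change taken in the opposite direction; the step of a number 3 percentage points lower from compound 1 to compound 3 (within the scatter), chloro in place of bromo, suggests the halogen itself matters little here. A modest rise is therefore expected, a number 10 percentage points higher from compound 1 to compound 4 (within the scatter). Compound 4 is thus estimated at 119%, within 105% to 133%.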

Compound 4, a percentage reported as activity, at one concentration (the size of the read-out at that concentration, not a potency): 123%
Beside the measured number, compound 4's estimate is 4 percentage points below it, and the stated range covers the measured number.
By their numbers in this assay, from the lowest: compounds 3, 1, 2 and 4 (each within the scatter of the next, the first and the last beyond it).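

In this assay, 3-bromophenyl in place of 4-bromophenyl gives a number 14 percentage points higher from compound 1 to compound 4 (beyond the scatter), so the difference first seen between the two chlorophenyl compounds also appears with bromo. The step with both groups changed points the same way, a number 17 percentage points higher from compound 3 to compound 4 (beyond the scatter), while bromo in place of chloro on an aromatic carbon gives a number 5 percentage points higher from compound 2 to compound 4 (within the scatter). The halogen swap reads alike with the group in either placement: the same change on two cores in this assay, a number 3 percentage points lower (within the scatter) from compound 1 to compound 3 and a number 5 percentage points lower (within the scatter) from compound 4 to compound 2, 2 percentage points apart, within the scatter of two such steps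

The compounds shown leave open whether a phenyl carrying an amine or a carboxylic acid in place of the halogen would follow the same order.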